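The compounds below may be only part of what the source reports. "The series", "measured", "known", "first", "only" and "open" are said of these compounds alone.

Two compounds carry the shared core. Compound 1 `CC1=CC[C@H](C(C)C)c2cc(C)c(OC(=O)Nc3ccccc3)cc21` gives 92.6% in a functional assay on K562 cells (Homo sapiens) for antiproliferative activity, read by sulforhodamine B assay, with a stated time of 48 h, tested at 50 uM; on this read-out lower numbers stand for less inhibition and higher numbers for more inhibition at the one concentration tested (going by the name of the read-out). Compound 2 `CC1=CC[C@H](C(C)C)c2cc(C)c(OC(=O)c3ccc(C(F)(F)F)cc3)cc21` gives 9% in this assay, the lowest of the two numbers; compound 1 sits well above it, beyond the scatter. Compound 3 `COc1ccc(C(=O)Oc2cc3c(cc2C)[C@@H](C(C)C)CC=C3C)cc1` is not yet measured and differs from compound 2 by methoxy in place of trifluoromethyl on an aromatic carbon. Among the measured compounds shown here, no measured step shows the effect of this change, so for compound 3 the value in this assay is expected to stay near that of compound 2, at about 15%, between 0% and 45%. The expected step of a number 6 percentage points higher from compound 2 to compound 3 (within the scatter) is estimated to lie within the scatter.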

Compound 3, a percentage reported as inhibition, at one concentration (the size of the read-out at that concentration, not a potency): 46.5%
Estimate against measurement, compound 3: 31.5 percentage points below, outside the stated range (above it).
By their numbers in this assay, from the lowest: compound 2; then compound 3; then compound 1.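

On the aromatic carbon para to a large group, methoxy in place of trifluoromethyl gives a number 37.5 percentage points higher from compound 2 to compound 3 (beyond the scatter) in this assay, the first sign that this position affects the read-out. On a carbonyl carbon, 4-methoxyphenyl in place of anilino gives a number 46.1 percentage points lower from compound 1 to compound 3 (beyond the scatter), which leaves the anilino compound ahead of the methoxy compound. Nothing available explains either step.

Still open, from the compounds shown here alone, is how an amine or a chlorine atom on that aromatic carbon would rank against methoxy and trifluoromethyl. Also open, going by these compounds, is whether a methoxy group on the anilino ring would keep the level of compound 1.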